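Sulfonamide series against mitochondrial malate dehydrogenase: working notes

The source may report more compounds than this note shows. Statements on the series, on what has been measured and on what is new or still open speak of the compounds shown alone.

Measured so far:
- Compound 1 `COc1ccccc1S(=O)(=O)Nc1ccc2oc(-c3ccccc3)nc2c1`: in an assay on isolated protein for inhibition of malate dehydrogenase, mitochondrial (Sus scrofa), with stated times of 45 min and 30 min (a higher number here means a weaker inhibitor, a lower number a stronger inhibitor), compound 1 gives > 63000 nM, which is a limit of the assay and not a number.
- Compound 2 `COc1ccccc1S(=O)(=O)Nc1ccc(-c2nc3ccccc3o2)cc1`: in this assay compound 2 gives > 63000 nM, again a limit of the assay.
- Compound 3 `CCc1ccc(S(=O)(=O)Nc2ccc3oc(-c4ccccc4)nc3c2)cc1`: in this assay compound 3 gives > 63000 nM, also a limit of the assay.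

Compound 1 and compound 3 differ in one place, (4-ethylphenyl in place of 2-methoxyphenyl on a sulfonyl sulfur). The step that the two limits leave unreadable from compound 1 to compound 3 cannot be read because of the limit of > 63000 nM in this assay, at which 3 of the 3 values shown sit; both ends of the step sit at that limit. Compound 2 has the same atoms as compound 1 joined differently; the difference between the two cores is not broken down here, and both values are limits of the same kind.

Compound 4 `CCc1ccc(S(=O)(=O)Nc2ccc(-c3nc4ccccc4o3)cc2)cc1` is not yet measured in this assay. Among the compounds with values here, it stands to compound 2 as compound 3 stands to compound 1: the change 4-ethylphenyl in place of 2-methoxyphenyl on a sulfonyl sulfur is the same change, at the same place, as the one from compound 1 to compound 3. Since the one measured instance of this change is unreadable because of the limit of > 63000 nM in this assay, at which 3 of the 3 values shown sit, the expectation for compound 4 rests only on the fact that every compound shown so far sits at the limit. The step from compound 2 to compound 4 is expected to be a step that the limit leaves unreadable from compound 2 to compound 4. For compound 4 in this assay the estimate is 100000 nM, within a range of 30000 nM to 400000 nM, most likely to be reported as a limit rather than a number.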

Compound 4, half-maximal inhibitory concentration: > 63000 nM
Compound 4: only a limit was reported (the forecaster's own chance of this, stated with the estimate: 85%); the middle value is on the limit's open side.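

In this assay compound 4 gives > 63000 nM, which is a limit of the assay and not a number. The step from compound 2 to compound 4 therefore cannot be read, as both ends sit at the same limit: the limit of > 63000 nM in this assay, at which 4 of the 4 values shown sit.

The compounds shown leave open whether 4-ethylphenyl or 2-methoxyphenyl on the sulfonyl sulfur, or either core, makes any readable difference to inhibition in this assay.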